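A few compounds are considered here, and "the series" means these few. Any claim that something is new, unique, unknown or untested is made for them only; others in the source may bear on it.

Compound 1, with the structure `CS(=O)(=O)N1CCN(CC(O)CN2CCC(CNC(=O)c3cccc4[nH]c(C5CC5)nc34)CC2)CC1`, and compound 2, with the structure `CC(=O)N1CCN(CCN2CCC(CNC(=O)c3cccc4[nH]c(C(C)C)nc34)CC2)CC1`, share one core and have both been run in a functional assay for agonist activity at 5-hydroxytryptamine receptor 4 (Homo sapiens), read by cAMP accumulation; a lower number here means that less compound is needed, a higher number that more compound is needed for the effect. In this assay compound 1 gives 0.631 nM, while compound 2 gives 3.16 nM, the higher of the two numbers and beyond the scatter from compound 1. The next compound, compound 3, has the structure `CC(=O)N(C)CC(O)CN1CCC(CNC(=O)c2cccc3[nH]c(C(C)C)nc23)CC1` and has not yet been measured. It is derived from compound 2 by the change (2-(acetyl(methyl)amino)-1-hydroxyethyl in place of (4-acetylpiperazin-1-yl)methyl on a saturated chain carbon bound to an amine nitrogen in a ring); cut one bond further out, the same difference reads 2-(4-acetylpiperazin-1-yl)ethyl to 3-(acetyl(methyl)amino)-2-hydroxypropyl. Within the data shown here, no measured pair here shows this kind of change, so no step can be quoted for it. Because compound 2 stands at 3.16 nM and the ring is opened, a modest move toward a higher number, close to the scatter, is expected: a 1.6-fold higher number from compound 2 to compound 3 (0.20 log units; within the scatter). Compound 3 is therefore estimated at 5 nM, with a range from 1.5 nM to 20 nM.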

Compound 3, half-maximal effective concentration: 1.59 nM
Compound 3: middle estimate off by 3.1-fold (0.50 log units), on the high side; low and high end bracket the measured number.
By their numbers in this assay, from the lowest: compound 1; then compounds 3 and 2 (each within the scatter of the next).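

In this assay, the difference between 2-(4-acetylpiperazin-1-yl)ethyl and 3-(acetyl(methyl)amino)-2-hydroxypropyl amounts to a 2.0-fold lower number from compound 2 to compound 3 (0.30 log units; within the scatter) and so does not separate the two compounds. At this place, on a saturated chain carbon bound to an amine nitrogen in a ring, the six-membered ring with its two hetero atoms can therefore give way to an open chain carrying a hydrogen-bond donor with no change beyond the scatter. Nothing measured here explains this result.

On these data alone, the ring and the hydroxyl group differ together in this pair, so the share of each remains open. Also open, as far as these compounds go, is how this place would respond to a chain ending in a primary amine or a carboxylic acid, or to a longer chain.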